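The source may hold more compounds than are shown below. What is called first, only, known or untested is meant among the compounds shown, and "the series" means these compounds.

The series rests on a shared core carrying a substituted piperazinylmethyl arm, and its compounds are tested in a functional assay on MCF7 cells (Homo sapiens) for cytotoxicity, read by sulforhodamine B assay, with a stated time of 48 h; on this read-out lower numbers stand for stronger inhibition of growth and higher numbers for weaker inhibition of growth. Compound 1 `O=C1C(=O)N(CN2CCN(c3ccnc4cc(Cl)ccc34)CC2)c2cc(Cl)ccc21` gives 26100 nM. Compound 2 `O=C1C(=O)N(CN2CCN(c3ccnc4cc(Cl)ccc34)CC2)c2cc(Br)ccc21` gives 17600 nM. The change between them is bromo in place of chloro on an aromatic carbon, and the step it makes is a 1.5-fold lower number from compound 1 to compound 2 (0.17 log units; within the scatter).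

Compound 3 `NC(=S)N/N=C1/C(=O)N(CN2CCN(c3ccnc4cc(C(F)(F)F)ccc34)CC2)c2cc(Cl)ccc21` carries a different core; how it differs from the core of compound 1 is not broken down here. In this assay compound 3 gives 24600 nM, a number that sits close to compound 1 and to compound 2, with every gap among the three within the scatter.

Compound 4 `NC(=S)N/N=C1/C(=O)N(CN2CCN(c3ccnc4cc(C(F)(F)F)ccc34)CC2)c2cc(Br)ccc21` has not yet been measured. Among the measured compounds shown here, it differs from compound 3 by bromo in place of chloro on an aromatic carbon, the same kind of change as the one from compound 1 to compound 2, made at a place described in the same words. That earlier step stayed within the scatter, so compound 4 is expected to show a step of a 1.4-fold lower number from compound 3 to compound 4 (0.14 log units; within the scatter), resting on the measured step from compound 1 to compound 2 of a 1.5-fold lower number from compound 1 to compound 2 (0.17 log units; within the scatter) and on the value of compound 3 of 24600 nM. The estimated value for compound 4 in this assay is 18000 nM, expected to fall between 9000 nM and 40000 nM.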

Compound 4, concentration for 50% growth inhibition: 35500 nM
Compound 4: middle estimate off by 2.0-fold (0.29 log units), on the low side, within the range that was stated.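

In this assay, bromo in place of chloro on an aromatic carbon gives a 1.4-fold higher number from compound 3 to compound 4 (0.16 log units; within the scatter), so on the core of compound 3 the change stays within the scatter, as it did on the core of compound 1. The two steps are printed in opposite directions, but that does not amount to a real difference between the cores, since the gap between the steps is itself no larger than the scatter of two such steps: the same change on two cores in this assay, a 1.5-fold lower number (0.17 log units; within the scatter) from compound 1 to compound 2 and a 1.4-fold higher number (0.16 log units; within the scatter) from compound 3 to compound 4, 2.1-fold (0.33 log units) apart, within the scatter of two such steps. This shows only that, on these two cores, the exchange of one halogen for the other produced no step beyond the scatter; it does not show that the change is without any effect, that a step of a given size or direction carries from one core to the other, or that the same would hold on any further core in the series.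

The compounds shown have only chloro or bromo at this place, so they leave open whether a group of another kind, such as methoxy, nitrile, an amine or a carboxylic acid, would give a step beyond the scatter on either core. They also leave open whether such a step, once seen on one core, would carry over to the other.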